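The compounds below may be only part of what the source reports. "The series", "measured", "known", "first", "only" and "open" are said of these compounds alone.

Two compounds share one core. Compound 1 `Cc1cc(Nc2cc(-c3ccccc3)[nH]n2)n2nc(SCCc3ccccc3)nc2n1` gives 2700 nM in a functional assay on MCF7 cells (Homo sapiens) for inhibition, read by MTT assay, with a stated time of 72 h; on this read-out higher numbers stand for weaker inhibition and lower numbers for stronger inhibition. Compound 2 `Cc1cc(Nc2cc(-c3ccccc3)[nH]n2)n2nc(SCc3ccc([N+](=O)[O-])cc3)nc2n1` gives 5060 nM in this assay, the higher of the two numbers shown, although the step of a 1.9-fold higher number from compound 1 to compound 2 (0.27 log units; within the scatter) stays within the scatter. Compound 3 `Cc1cc(Nc2cc(-c3ccccc3)[nH]n2)n2nc(SCc3csc4ccccc34)nc2n1` differs from compound 2 by 1-benzothiophen-3-yl in place of 4-nitrophenyl on a saturated chain carbon bound to a sulfur. Among the compounds with values here, no measured step introduces a 1-benzothiophen-3-yl at this place, and the only step known at this place, from benzyl to 4-nitrophenyl, stayed within the scatter, so no movement beyond the scatter is expected here either. Compound 3 is therefore estimated at 3500 nM, between 1200 nM and 10000 nM, an expected step of a 1.4-fold lower number from compound 2 to compound 3 (0.16 log units; within the scatter).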

Compound 3, half-maximal inhibitory concentration: 3470 nM
For compound 3 the middle estimate is 1.0-fold (0.00 log units) above the measured one; measured number inside the range.
By their numbers in this assay, from the lowest: compounds 1, 3 and 2 (each within the scatter of the next).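

In this assay, 1-benzothiophen-3-yl in place of 4-nitrophenyl gives a 1.5-fold lower number from compound 2 to compound 3 (0.16 log units; within the scatter), and the same group in place of benzyl gives a 1.3-fold higher number from compound 1 to compound 3 (0.11 log units; within the scatter). So a group with a five-membered aromatic ring added to a six-membered one also reads the same as the other two groups on this saturated chain carbon bound to a sulfur. No supporting data explain this sameness. As far as these compounds go, whether an amine, a carboxylic acid or a longer chain at this place would move the number beyond the scatter remains open.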